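The source may report more compounds than this note shows. Statements on the series, on what has been measured and on what is new or still open speak of the compounds shown alone.

Series notes, a functional assay on A549 cells (Homo sapiens) for antiproliferative activity, read by MTT assay, with a stated time of 72 h; on this read-out higher numbers stand for weaker inhibition and lower numbers for stronger inhibition:

- compound 1 `COc1cc(-n2cnc3ccc(-c4cccc(F)c4)cc32)cc(OC)c1OC`: 5270 nM
- compound 2 `COc1cc(-n2cnc3ccc(-c4ccc(Cl)cc4)cc32)cc(OC)c1OC`: > 10000 nM

For the measured compounds named here, for compound 2 only a limit is available, > 10000 nM, not a number. the limit of > 10000 nM in this assay, at which 1 of the 2 values shown sits, is the only such reading among the two values, so the exact standing of compound 2 remains unresolved. The next compound, compound 3 `COc1cc(-n2cnc3ccc(-c4ccc(Cl)cc4Cl)cc32)cc(OC)c1OC`, turns 4-chlorophenyl into 2,4-dichlorophenyl, with chloro in place of hydrogen on an aromatic carbon.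

Going by the values given here, one measured step bears on this, and only indirectly: an at least 1.8-fold higher number from compound 1 to compound 2 (0.27 log units; that floor lies within the scatter). That step also changes the substituents on the phenyl group, but it swaps one halogen pattern for another and its size is only a floor. Among the compounds with values here, no measured pair shows the addition of a second chloro, so the data give no direction for this change. No step beyond the scatter is expected in this assay, and the reading may again be only a limit. The expected step is a step that the limit leaves unreadable from compound 2 to compound 3. For compound 3 the estimate is 12000 nM, with an expected range of 4000 nM to 35000 nM.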

Compound 3, half-maximal inhibitory concentration: > 10000 nM
Compound 3: only a limit was reported; the forecaster's own chance of this, stated with the estimate: 65%; the middle value is on the limit's open side.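

In this assay compound 3 gives > 10000 nM, which is a limit and not a number, so chloro in place of hydrogen ortho to a large group yields no measurable reading. The step between compound 2 and compound 3 cannot be read, and the second chloro therefore has neither a size nor a direction here, but a second chlorophenyl pattern now ends at the same limit: the limit of > 10000 nM in this assay, at which 2 of the 3 values shown sit. For the compounds shown here, the only readable comparison is an at least 1.8-fold higher number from compound 1 to compound 3 (0.27 log units; that floor lies within the scatter), a floor that matches the one for the 4-chlorophenyl change and leaves compound 1 as the only compound of the three with a numerical reading.

Going by these compounds, it remains open how far compound 2 and compound 3 actually lie from each other, and whether either truly differs from compound 1 by more than the scatter. Also open, on these data alone, is how a phenyl group carrying an amine or a carboxylic acid in place of the halogens would read in this assay.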